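The source may hold more compounds than are shown below. What is called first, only, known or untested is meant among the compounds shown, and "the series" means these compounds.

Of the compounds shown here, two have numbers so far. In an ADME assay on microsomes from liver (Mus musculus) for metabolic stability (a higher number here means faster removal of the compound, a lower number slower removal), compound 1 `Cc1n[nH]c(-c2ncc3cccnc3c2O)n1` gives 3.3 mL.min-1.g-1 and compound 2 `CNc1ccnc2c(O)c(-c3nc(C)n[nH]3)ncc12` gives 3.1 mL.min-1.g-1 so compound 2 stands level with compound 1, the two lying within the scatter of each other. Compound 3 `Cc1n[nH]c(-c2ncc3c(N(C)C)ccnc3c2O)n1` alters compound 2 in one place, where methyl replaces hydrogen on a nitrogen on an aromatic ring, turning methylamino into dimethylamino (methyl in place of hydrogen on a nitrogen on an aromatic ring). Among the compounds with values here, one measured step bears on this, the one that put methylamino in place of hydrogen on an aromatic carbon, and its size (a 1.1-fold lower number from compound 1 to compound 2 (0.03 log units; within the scatter)) gives little to build on. A single step on a different change is thin evidence, but it offers no reason to expect movement, so no shift beyond the scatter is expected in this assay here. The expected step is small (a 1.1-fold higher number from compound 2 to compound 3 (0.05 log units; within the scatter)). Compound 3 is estimated at 3.5 mL.min-1.g-1 with an expected range from 1.8 mL.min-1.g-1 to 7 mL.min-1.g-1 in this measurement.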

Compound 3, intrinsic clearance in microsomes: 14 mL.min-1.g-1
The estimate for compound 3 lay 4.0-fold (0.60 log units) below the measured number; the measured number lies above the stated range.
By their numbers in this assay, from the lowest: compounds 2 and 1 (each within the scatter of the next); then compound 3.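

At this position a single added methyl changes the picture: in this assay the move from methylamino to dimethylamino gives a 4.5-fold higher number from compound 2 to compound 3 (0.65 log units; beyond the scatter), whereas the first substitution, methylamino for hydrogen, gave only a 1.1-fold lower number from compound 1 to compound 2 (0.03 log units; within the scatter). Measured against the unsubstituted core, the full dimethylamino group gives a 4.2-fold higher number from compound 1 to compound 3 (0.63 log units; beyond the scatter), so the rise appears only once the nitrogen carries its second methyl. Nothing available here accounts for this jump.

Still open, on these data alone, is whether the rise is particular to dimethylamino or would also come with a longer chain on this nitrogen, such as ethylamino, or with a ring amine such as pyrrolidine. As far as these compounds go, it is equally open whether a group joined through oxygen, such as methoxy, would stay level with compound 1.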